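This account rests on a few compounds, and the source may have more. Where it says the series, first, only, none or still open, it means among the compounds named here.

Compound 1, `CC1=CC[C@H](C(C)(C)NC(=S)N/N=C/c2ccccc2O)CC1`, is the reference point in this small series. In a functional assay on 786-0 cells (Homo sapiens) for inhibition, read by sulforhodamine B assay, with a stated time of 48 h (on this read-out higher numbers stand for weaker inhibition of growth and lower numbers for stronger inhibition of growth), compound 1 gives 12100 nM. Compound 2, `CC1=CC[C@H](C(C)(C)NC(=S)N/N=C/c2ccc(N(C)C)cc2)CC1`, carries a dimethylamino group on the aromatic ring in place of the hydroxy group of compound 1. For compound 2 this assay reports only a limit, > 100000 nM, and not a number. That limit is the limit of > 100000 nM in this assay, at which 1 of the 2 values shown sits, so compound 2 stands at the weak end of everything shown here, with no measured gap to compound 1 that can be sized.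

Compound 3, `CC1=CC[C@H](C(C)(C)NC(=S)N/N=C/c2ccc(Cl)cc2)CC1`, has not yet been measured. It differs from compound 2 by chloro in place of dimethylamino on an aromatic carbon, on an aromatic carbon of a six-membered aromatic ring of carbon only, para to a large group. For the measured compounds named here, no step between two measured compounds in this assay can be carried over to this change, so the expectation rests on compound 2 alone. Since compound 2 sits at a limit, the step in this assay is expected to run toward stronger inhibition of growth, of moderate size, though it may stay within the scatter. Compound 3 is therefore estimated at 40000 nM, between 8000 nM and 150000 nM, which would mean a step of an at least 2.5-fold lower number from compound 2 to compound 3 (0.39 log units; beyond the scatter).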

Compound 3, concentration for total growth inhibition: > 100000 nM
Compound 3 ended at the assay's limit; the forecaster's own chance of this, stated with the estimate: 35%; middle value at least 2.5-fold (0.39 log units) away from the limit.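

In this assay compound 3 gives only a limit, > 100000 nM and not a number, so chloro in place of dimethylamino on this aromatic carbon, para to a large group, does not bring the compound off the limit. The step between the two compounds cannot be read, and they now share the weak end of the series: the limit of > 100000 nM in this assay, at which 2 of the 3 values shown sit. The change of 4-chlorophenyl in place of 2-hydroxyphenyl gives an at least 8.2-fold higher number from compound 1 to compound 3 (0.91 log units; beyond the scatter) and so, with both dimethylamino and chloro on the ring, only compound 1 of the three gives a number.

Going by these compounds, whether that number goes with the hydroxy group itself or with where it sits stays open, and a 4-hydroxyphenyl or a 2-chlorophenyl group in the same core would be needed to separate the two. Also open, on these data alone, is whether any other group in the place of chloro, such as a methoxy group or a carboxylic acid, would give a readable value at all.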